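From 4-nitrophenyl to 2-nitrophenyl: working notes on the series

The compounds below may be only part of what the source reports. "The series", "measured", "known", "first", "only" and "open" are said of these compounds alone.

- compound 1 `c1ccc(COc2ccc(OCCOCCNC3CCCC3)cc2)cc1`: 24800 nM
- compound 2 `O=[N+]([O-])c1ccc(COc2ccc(OCCOCCNC3CCCC3)cc2)cc1`: 20300 nM

In a functional assay on SK-OV-3 cells (Homo sapiens) for inhibition, read by CCK-8 assay, with a stated time of 70 h (on this read-out higher numbers stand for weaker inhibition and lower numbers for stronger inhibition), compound 2 stands at 20300 nM, within the scatter of compound 1. Compound 3 `O=[N+]([O-])c1ccccc1COc1ccc(OCCOCCNC2CCCC2)cc1` differs from compound 2 as follows: 2-nitrophenyl in place of 4-nitrophenyl on a saturated chain carbon bound to an oxygen on an aromatic ring. Within the data shown here, the only measured step, a 1.2-fold lower number from compound 1 to compound 2 (0.09 log units; within the scatter), puts a nitro group in place of hydrogen and says nothing direct about changing its place. No step beyond the scatter is therefore expected in this assay. The estimated step is a 1.0-fold lower number from compound 2 to compound 3 (0.01 log units; within the scatter). For compound 3 the estimated value is 20000 nM, with an expected range of 10000 nM to 40000 nM.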

Compound 3, half-maximal inhibitory concentration: 5370 nM
Compound 3: middle estimate off by 3.7-fold (0.57 log units), on the high side; the measured number lies below the stated range.
By their numbers in this assay, from the lowest: compound 3; then compounds 2 and 1 (each within the scatter of the next).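

Where the nitro group sits on the ring matters in this assay: 2-nitrophenyl in place of 4-nitrophenyl gives the first step beyond the scatter in the series (a 3.8-fold lower number from compound 2 to compound 3 (0.58 log units; beyond the scatter)). Nitro in place of hydrogen on an aromatic carbon thus counts here only as 2-nitrophenyl (a 4.6-fold lower number from compound 1 to compound 3 (0.66 log units; beyond the scatter)), whereas 4-nitrophenyl stays within the scatter (a 1.2-fold lower number from compound 1 to compound 2 (0.09 log units; within the scatter)). Nothing at hand accounts for this difference between the two placements.

Open, going by these compounds, is whether the lower number belongs to the nitro group itself or would also come with an amine or a nitrile in its place. On these data alone, the standing of 3-nitrophenyl also stays open.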